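The compounds below may be only part of what the source reports. "The series", "measured", "known", "first", "only" and "open" are said of these compounds alone.

Measured so far:
compound 1 `O=C1C(=O)N(Cc2ccc(-c3cncnc3)cc2)c2ccc(OC(F)(F)F)cc21`: 2100 nM
compound 2 `O=C1C(=O)N(Cc2ccc(-c3ccccc3)cn2)c2ccc(OC(F)(F)F)cc21`: 3100 nM

In a functional assay on CHO cells for positive allosteric modulation of muscarinic acetylcholine receptor M5 (Homo sapiens), read by FLIPR and calcium flux, with a stated time of 1 h (on this read-out lower numbers stand for an effect already at smaller amounts and higher numbers for an effect only at larger amounts of compound), compound 1 gives 2100 nM, the lower of the two numbers, though compound 2 at 3100 nM lies within the scatter of it, so the two cannot be ordered. Compound 3 `O=C1C(=O)N(Cc2ccc(Oc3ccccn3)cc2)c2ccc(OC(F)(F)F)cc21` is not yet measured. It differs from compound 1 by (pyridin-2-yl)oxy in place of pyrimidin-5-yl on an aromatic carbon. Among the compounds with values here, no measured pair shows this change, so nothing is known of its size. No step beyond the scatter is expected in either direction. Compound 3 is expected to give 2500 nM, with a range of 800 nM to 8000 nM. The expected step is a 1.2-fold higher number from compound 1 to compound 3 (0.08 log units; within the scatter).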

Compound 3, half-maximal effective concentration: 3200 nM
The estimate for compound 3 lay 1.3-fold (0.11 log units) below the measured number; measured number inside the range.
By their numbers in this assay, from the lowest: compounds 1, 2 and 3 (each within the scatter of the next).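

In this assay, (pyridin-2-yl)oxy in place of pyrimidin-5-yl, on an aromatic carbon para to a large group, gives a 1.5-fold higher number from compound 1 to compound 3 (0.18 log units; within the scatter) and thus no step beyond the scatter. This position therefore tolerates this exchange of one aromatic ring for another attached through oxygen, at least for this pair. Nothing measured here accounts for the result.

Still open, as far as these compounds go, is whether a non-aromatic group here, such as an amine, a carboxylic acid or a longer chain, would stay within the scatter of compound 1. Also open, from the compounds shown here alone, is whether any group at this position gives a step beyond the scatter.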